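Swapping a Sulfonamide-Bearing Ring for a Styryl Chain

The source may report more compounds than this note shows. Statements on the series, on what has been measured and on what is new or still open speak of the compounds shown alone.

Compound 1, `CC(C)(N)C(=O)N[C@H](COCc1ccccc1)c1nnn(Cc2ccc(NS(C)(=O)=O)cc2)n1`, in an assay on isolated protein for displacement of a labelled ligand from growth hormone secretagogue receptor type 1 (Homo sapiens), with a stated time of 1 h (a lower number here means a stronger inhibitor, a higher number a weaker inhibitor), gives only the limit > 5000 nM.
Compound 2, `CC(C)(N)C(=O)N[C@H](COCc1ccccc1)c1nnn(Cc2cccc(NS(C)(=O)=O)c2)n1`, in this assay gives only the limit > 5000 nM.

Going by the values given here, compound 2 therefore stands at the boundary of what this assay can report, and the one measured step, a step that the two limits leave unreadable from compound 1 to compound 2, cannot be sized because of the limit of > 5000 nM in this assay, at which 2 of the 2 values shown sit. Compound 3, `CC(C)(N)C(=O)N[C@H](COCc1ccccc1)c1nnn(C/C=C/c2ccccc2)n1`, is the next compound: 2-phenylethenyl in place of 3-(methanesulfonamido)phenyl on a saturated chain carbon bound to an aromatic nitrogen. No measured step with a readable size bears on this change, since both shown values are limits, so there is no basis for expecting a move in either direction beyond the scatter. The expectation is that compound 3 stays near the same boundary, an estimated 5000 nM with a range from 800 nM to 30000 nM. The step this estimate implies, a number no higher from compound 2 to compound 3 (the limit leaves the size open), is expected to be small and uncertain, with a fair chance that only a limit is reported again.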

Compound 3, inhibition constant: > 5000 nM
Compound 3: a limit, no number; the forecaster's own chance of this, stated with the estimate: 55%; the middle value lies on the limit itself.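

In this assay compound 3 gives > 5000 nM, which is a limit and not a number. The steps from compound 1 and compound 2 to compound 3 cannot be read because all three compounds share one limit: the limit of > 5000 nM in this assay, at which 3 of the 3 values shown sit.

The compounds shown leave open how strongly each one binds, and whether 2-phenylethenyl or either methanesulfonamido-bearing ring makes any difference.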